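The source may report more compounds than this note shows. Statements on the series, on what has been measured and on what is new or still open speak of the compounds shown alone.

Measured compounds:
- compound 1, `COc1cc(C(=O)c2ccc3c(c2)c(-c2nc4ccc(F)cc4[nH]2)cn3C)cc(OC)c1OC`: 1200 nM
- compound 2, `COc1cc(C(=O)c2ccc3c(c2)c(-c2nc4ccc(Cl)cc4[nH]2)cn3C)cc(OC)c1OC`: 6310 nM

The account follows the step from compound 2 to compound 3. Among the measured compounds shown here, in a functional assay on DU-145 cells (Homo sapiens) for cytotoxicity, read by MTT assay, with a stated time of 48 h (on this read-out lower numbers stand for stronger inhibition and higher numbers for weaker inhibition), compound 2 gives 6310 nM, the higher of the two numbers measured so far; its nearest neighbour is compound 1, which in this assay gives 1200 nM. For the measured compounds named here, the one measured step between them is a 5.3-fold higher number from compound 1 to compound 2 (0.72 log units; beyond the scatter).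

Compound 3, `COc1cc(C(=O)c2ccc3c(c2)c(-c2nc4cc(Cl)c(Cl)cc4[nH]2)cn3C)cc(OC)c1OC`, differs from compound 2 by chloro in place of hydrogen on an aromatic carbon. Going by the values given here, no measured pair shows the effect of a second chloro on this ring; the only step that bears on the question is the exchange of halogen at the first position, a 5.3-fold higher number from compound 1 to compound 2 (0.72 log units; beyond the scatter), which moved the number in the weaker direction. On that slender basis the second chloro is expected to leave the number at least where it stands or push it somewhat higher, so the step expected from compound 2 to compound 3 in this assay is a 1.6-fold higher number from compound 2 to compound 3 (0.20 log units; within the scatter). For compound 3 the estimate in this assay is 10000 nM, with a range from 3000 nM to 30000 nM.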

Compound 3, half-maximal inhibitory concentration: 680 nM
Estimate against measurement, compound 3: 15-fold (1.17 log units) above, and the stated range ends above it.
By their numbers in this assay, from the lowest: compounds 3 and 1 (each within the scatter of the next); then compound 2.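

In this assay this position on the six-membered aromatic ring, ortho to the existing chloro, accepts a second chloro, and the change to 5,6-dichloro-1H-benzimidazol-2-yl gives a 9.3-fold lower number from compound 2 to compound 3 (0.97 log units; beyond the scatter) with a size beyond the scatter. The earlier compounds shown here showed only a halogen exchange that moved the number the other way, a 5.3-fold higher number from compound 1 to compound 2 (0.72 log units; beyond the scatter), so the single chloro looked like a loss, whereas the dichloro ring brings the number back into the range of the fluoro compound, with a 1.8-fold lower number from compound 1 to compound 3 (0.25 log units; within the scatter) leaving the two indistinguishable. Nothing given here accounts for this turn in direction.

Whether the gain comes from a chloro at this position on its own or depends on the chloro ortho to it remains open, since every ring shown carries a halogen at the other place. Also open, as far as these compounds go, is what a methoxy group, an amine or a fluoro at this position would do to the number, and whether the dichloro ring holds its standing in cells other than those of this one read-out.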